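Removing the amino group from a quinoline-type core

The source may report more compounds than this note shows. Statements on the series, on what has been measured and on what is new or still open speak of the compounds shown alone.

Measured so far:
Compound 1, `Fc1cccc(F)c1C#Cc1ccc2nccc(Cl)c2c1`, gives 43.8%.
Compound 2, `Nc1ccnc2ccc(C#Cc3c(F)cccc3F)cc12`, gives 66.2%.

Both numbers come from a functional assay on LS174T cells (Homo sapiens) for inhibition, with a stated time of 4 days, tested at 1 uM; a lower number here means a weaker effect, a higher number a stronger effect of the compound at the concentration tested. Compound 2 stands highest of the two, and the gap to compound 1 lies beyond the scatter: a number 22.4 percentage points higher from compound 1 to compound 2 (beyond the scatter). That single step is the only one measured, and it shows that the amino group goes with the stronger effect in this assay.

Compound 3, `Fc1cccc(F)c1C#Cc1ccc2ncccc2c1`, has not been measured. It differs from compound 2 as follows: hydrogen in place of amino on an aromatic carbon. Among the measured compounds shown here, the only measured step that bears on this change is the one from compound 1 to compound 2, which is modest and points towards the amino group. Taking the amino group away is therefore expected to lower the number, and the estimated step is a number 24.2 percentage points lower from compound 2 to compound 3 (beyond the scatter). For the measured compounds named here, with no measured compound carrying hydrogen at that place, the range is kept wide. Compound 3 is expected to give 42%, with a range from 22% to 62%.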

Compound 3, a percentage reported as inhibition, at one concentration (the size of the read-out at that concentration, not a potency): 11%
Compound 3: the middle estimate sits 31 percentage points above what was measured, outside the stated range (below it).
By their numbers in this assay, from the lowest: compound 3; then compound 1; then compound 2.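

In this assay, hydrogen at this place gives the weakest effect of the three compounds: replacing the amino group gives a number 55.2 percentage points lower from compound 2 to compound 3 (beyond the scatter), and replacing the chloro group gives a number 32.8 percentage points lower from compound 1 to compound 3 (beyond the scatter). The earlier step showed only that amino outperformed chloro, whereas these steps show that both groups go with a stronger effect than hydrogen, so the chloro group also counts for something at this place. No evidence is available on what lies behind this order.

From the compounds shown here alone, it remains open whether a methylamino group, a methoxy group or a hydroxyl group at this place would stand above or below the amino group. Also open, going by these compounds, is whether the same order would hold with a different group in place of the rest of the shared structure.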